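The compounds below may be only part of what the source reports. "The series", "measured", "known", "first", "only" and "open" are said of these compounds alone.

Compounds with measured values:
compound 1, `COc1cc(/C=C/C(=O)/C=C/c2cc(OC)c(OC)c(OC)c2)ccc1OCc1cn(CCCCCOc2cc(=O)oc3ccccc23)nn1`, 53%;
compound 2, `COc1cc(/C=C/C(=O)/C=C/c2ccccc2)ccc1OCc1cn(CCCCCOc2cc(=O)oc3ccccc23)nn1`, 24%;
compound 3, `COc1cc(/C=C/C(=O)/C=C/c2ccco2)ccc1OCc1cn(CCCCCOc2cc(=O)oc3ccccc23)nn1`, 37%.

All three were tested in a functional assay on HCT-116 cells (Homo sapiens) for inhibition, read by sulforhodamine B assay, with a stated time of 48 h, tested at 50 uM; a lower number here means less inhibition of growth, a higher number more inhibition of growth at the concentration tested. Among these numbers compound 3 stands second highest: its nearest neighbour is compound 2, with a number 13 percentage points higher from compound 2 to compound 3 (beyond the scatter), and the furthest is compound 1, with a number 16 percentage points lower from compound 1 to compound 3 (beyond the scatter).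

Compound 4, `COc1cc(/C=C/C(=O)/C=C/c2cccc3ccccc23)ccc1OCc1cn(CCCCCOc2cc(=O)oc3ccccc23)nn1`, has not yet been measured. It differs from compound 3 in one place: naphthalen-1-yl in place of furan-2-yl on a double-bonded chain carbon bound to a double-bonded chain carbon. Among the compounds with values here, two measured steps concern the same place. The change from 3,4,5-trimethoxyphenyl to phenyl gave a number 29 percentage points lower from compound 1 to compound 2 (beyond the scatter), and the change from phenyl to furan-2-yl gave a number 13 percentage points higher from compound 2 to compound 3 (beyond the scatter). Neither step shows what an aromatic group of two carbon-only rings does there, so the direction for compound 4 is uncertain, and only a modest step is expected, which is put as a number 2 percentage points lower from compound 3 to compound 4 (within the scatter). For compound 4 the expected value in this assay is therefore 35%, with a range from 15% to 55%.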

Compound 4, percent growth inhibition at one concentration: 42%
The estimate for compound 4 lay 7 percentage points below the measured number; the range from low to high includes it.
By their numbers in this assay, from the lowest: compound 2; then compounds 3 and 4 (each within the scatter of the next); then compound 1.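

In this assay, within the data shown here, naphthalen-1-yl is the first group with two carbon-only aromatic rings at this position, and it gives a number 5 percentage points higher from compound 3 to compound 4 (within the scatter) when it replaces furan-2-yl, so these two groups cannot be told apart here. The same group gives a number 18 percentage points higher from compound 2 to compound 4 (beyond the scatter) when it replaces phenyl, showing that a larger aromatic group without substituents can differ from phenyl here, yet the replacement of 3,4,5-trimethoxyphenyl gives a number 11 percentage points lower from compound 1 to compound 4 (beyond the scatter) and leaves compound 1 the highest of the four. Nothing at hand explains these differences. 

The compounds shown leave open whether a single methoxy group on the phenyl would account for part of the gap to compound 1. They also leave open how an amine or a carboxylic acid would fare at this position.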